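The source may hold more compounds than are shown below. What is called first, only, known or untested is meant among the compounds shown, and "the series" means these compounds.

Measured so far in a functional assay on isolated protein for inhibition of Glucose-dependent insulinotropic receptor (Homo sapiens), read by HTRF and cAMP accumulation; a lower number here means that less compound is needed, a higher number that more compound is needed for the effect:

compound 1 `Cc1nc(S(C)(=O)=O)ccc1Oc1ncnc(OC2CCN(C(=O)OC3CCC3)CC2)c1F`: 13.6 nM
compound 2 `Cc1nc(S(C)(=O)=O)ccc1Oc1ncnc(OC2CCN(C(=O)O[C@H](C)C(F)(F)F)CC2)c1F`: 9.2 nM
compound 3 `Cc1nc(S(C)(=O)=O)ccc1Oc1ncnc(OC2CCN(C(=O)SC3CCC3)CC2)c1F`: 8.51 nM

All three numbers lie within the scatter of one another. Compound 1 sits at the high end of the set: its step to compound 2 is a 1.5-fold lower number from compound 1 to compound 2 (0.17 log units; within the scatter) and its step to compound 3 is a 1.6-fold lower number from compound 1 to compound 3 (0.20 log units; within the scatter), both within the scatter, and the gap between compound 2 and compound 3 is a 1.1-fold lower number from compound 2 to compound 3 (0.03 log units; within the scatter).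

Compound 4 `Cc1nc(S(C)(=O)=O)ccc1Oc1ncnc(OC2CCN(C(=O)C(C)(F)F)CC2)c1F` is the next member to be measured. Its difference from compound 1 is 1,1-difluoroethyl in place of cyclobutyloxy on a carbonyl carbon. Going by the values given here, no measured pair carries out exactly this change. The two steps that come closest, from compound 1, are the exchange of the cyclobutyl on the oxygen for 1-(trifluoromethyl)ethyl in a 1.5-fold lower number from compound 1 to compound 2 (0.17 log units; within the scatter), and the exchange of cyclobutyloxy for cyclobutylsulfanyl in a 1.6-fold lower number from compound 1 to compound 3 (0.20 log units; within the scatter); each touched the same carbonyl carbon and each stayed within the scatter. On that basis a step of a 1.1-fold lower number from compound 1 to compound 4 (0.05 log units; within the scatter) is expected for compound 4, that is, no movement beyond the scatter in this assay, with the range kept wide because the oxygen itself is removed here.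

For compound 4 the estimate in this assay is 12 nM, with an expected range from 5 nM to 30 nM.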

Compound 4, half-maximal effective concentration: 37 nM
Compound 4: the middle estimate sits 3.1-fold (0.49 log units) below what was measured; the measured number lies above the stated range.
By their numbers in this assay, from the lowest: compounds 3, 2 and 1 (each within the scatter of the next); then compound 4.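

At the carbonyl carbon whose other neighbour is the amide-type nitrogen in a ring, this assay now shows a change beyond the scatter: 1,1-difluoroethyl in place of cyclobutyloxy gives a 2.7-fold higher number from compound 1 to compound 4 (0.43 log units; beyond the scatter) and the same group gives a 4.3-fold higher number from compound 3 to compound 4 (0.64 log units; beyond the scatter) against cyclobutylsulfanyl and a 4.0-fold higher number from compound 2 to compound 4 (0.60 log units; beyond the scatter) against 1-(trifluoromethyl)ethoxy. Going by these compounds alone, compounds 1, 2 and 3, which carry oxygen or sulfur on this carbonyl carbon, stay within the scatter of one another, while compound 4, with carbon there, stands apart from all of them, so this position does not tolerate every exchange as the earlier compounds alone might have suggested. This one exchange removes the oxygen and the four-membered ring and brings in fluorine all at once, so the step cannot be assigned to any one of these parts, and no measurement at hand offers an explanation for it.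

Open, going by these compounds, is whether 1,1-difluoroethoxy, which would restore the oxygen, falls with compound 1 or with compound 4. Equally open, on these data alone, is where a plain cyclobutyl or a cyclobutylamino group on this carbonyl carbon would fall.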